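This account rests on a few compounds, and the source may have more. Where it says the series, first, only, none or still open, it means among the compounds named here.

Working notes on the series in a functional assay on the whole organism for positive allosteric modulation, with Mus musculus as the target; on this read-out lower numbers stand for an effect already at smaller amounts and higher numbers for an effect only at larger amounts of compound. Of the compounds shown here, three on the shared core have been measured: compound 1 (`CCC(=O)N(c1ccc(F)cc1)C1CCCC1N(C)C`) gives 5 mg/kg, compound 2 (`CCC(=O)N(c1cccc(Cl)c1)C1CCCC1N(C)C`) gives 0.4 mg/kg and compound 3 (`CCC(=O)N(c1ccc(C)c(Cl)c1)C1CCCC1N(C)C`) gives 1 mg/kg. Compound 3 therefore stands in the middle of the three numbers, clear of both neighbours.

The next entry is compound 4 (`CCC(=O)N(c1ccc(F)c(Cl)c1)C1CCCC1N(C)C`), which has fluoro in place of methyl on an aromatic carbon, ortho to a chloro group and para to a large group: fluoro in place of methyl on an aromatic carbon.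

Among the measured compounds shown here, one measured step bears directly on this change. It is a 2.5-fold higher number from compound 2 to compound 3 (0.40 log units; beyond the scatter), a modest rise on adding the methyl that compound 4 lacks. For the measured compounds named here, no measured compound carries fluoro together with the chloro group. Compound 1 carries fluoro without the chloro group and gives 5 mg/kg, but it is no clean partner for this comparison, as it differs from compound 3 in more than one place.

In this assay, a step toward lower numbers is expected, no larger than the methyl step and possibly not clear of the scatter. The expected change is a 1.7-fold lower number from compound 3 to compound 4 (0.22 log units; within the scatter). For compound 4 the estimate is 0.6 mg/kg, with an expected range of 0.2 mg/kg to 2 mg/kg.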

Compound 4, dose for half-maximal effect: 0.2 mg/kg
For compound 4 the middle estimate is 3.0-fold (0.48 log units) above the measured one, and the stated range covers the measured number.
By their numbers in this assay, from the lowest: compounds 4 and 2 (each within the scatter of the next); then compound 3; then compound 1.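

In this assay, on this aromatic carbon, ortho to a chloro group and para to a large group, fluoro in place of methyl gives a 5.0-fold lower number from compound 3 to compound 4 (0.70 log units; beyond the scatter), so the two groups are clearly not interchangeable here. Fluoro in place of hydrogen gives a 2.0-fold lower number from compound 2 to compound 4 (0.30 log units; within the scatter), which leaves fluoro and hydrogen unresolved at this position, whereas methyl in place of hydrogen gives a 2.5-fold higher number from compound 2 to compound 3 (0.40 log units; beyond the scatter); only the methyl step is beyond the scatter. With fluoro at this carbon, chloro in place of hydrogen gives a 25-fold lower number from compound 1 to compound 4 (1.40 log units; beyond the scatter), the largest of the steps at hand, although no measurement available here accounts for any of these steps.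

Going by these compounds, whether the lower number seen with fluoro or hydrogen at this carbon would hold for a methoxy group, a nitrile or an amine remains open, as does the outcome of bromo in place of the chloro group. Also open, on these data alone, is whether these steps would keep their size with a longer chain on the carbonyl or with a larger amine in place of the dimethylamino group.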